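Cytotoxicity notes: ketone side chain exchange

A few compounds are considered here, and "the series" means these few. Any claim that something is new, unique, unknown or untested is made for them only; others in the source may bear on it.

Measured so far in an ADME assay on L929 cells (Mus musculus) for cytotoxicity, read by resazurin assay, with a stated time of 72 h; a higher number here means a weaker inhibitor, a lower number a stronger inhibitor:
compound 1, `OB1OCc2ccc(-n3cccc3Sc3ccccc3Cl)cc21`, gives > 10 ug/mL, a limit of this assay.
compound 2, `O=C(c1ccc(Cl)cc1)c1ccn(-c2ccc3c(c2)B(O)OC3)c1`, gives > 10 ug/mL, likewise a limit of this assay.

Neither value is a number. For the measured compounds named here, compound 2 therefore stands nowhere on a scale in this assay; its result is only a limit, and the one further value shown is a limit as well. Going by the values given here, the whole of the evidence is the limit of > 10 ug/mL in this assay, at which 2 of the 2 values shown sit, so no step between measured compounds can be drawn and no direction is set by the data.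

Compound 3, `NCCCC(=O)c1ccn(-c2ccc3c(c2)B(O)OC3)c1`, is to be measured in this assay. It differs from compound 2 by 3-aminopropyl in place of 4-chlorophenyl on a carbonyl carbon.

With both measured values sitting at the limit, no step beyond the scatter is expected in either direction, and the most likely outcome is that compound 3 also reports only the limit rather than a number. The expected step is a step that the limit leaves unreadable from compound 2 to compound 3. Compound 3 is estimated at 15 ug/mL, with a range from 5 ug/mL to 50 ug/mL, the upper part of that range being the more probable.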

Compound 3, half-maximal inhibitory concentration: > 10 ug/mL
Compound 3 was reported as a limit (the forecaster's own chance of this, stated with the estimate: 75%); the middle value does not contradict the limit.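

In this assay compound 2 and compound 3 both report only a limit, so no step can be read between them: the limit of > 10 ug/mL in this assay, at which 3 of the 3 values shown sit.

The compounds shown leave open whether 3-aminopropyl in place of 4-chlorophenyl on a carbonyl carbon shifts the read-out at all, and where compound 1, compound 2 and compound 3 would fall as numbers in this assay.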